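Swapping a hydroxy group for a methoxy group

A few compounds are considered here, and "the series" means these few. Any claim that something is new, unique, unknown or untested is made for them only; others in the source may bear on it.

- compound 1 (`COc1ccc(CN2C(=O)/C(=C\c3cc(OC)c(OC)c(OC)c3)c3ccccc32)cc1`): 1800 nM
- compound 2 (`COc1cc(/C=C2/C(=O)N(C)c3ccc(O)cc32)cc(OC)c1OC`): 4300 nM

In a functional assay on cells (Cancer cell lines, Homo sapiens) for cytotoxicity, with a stated time of 48 h (on this read-out higher numbers stand for weaker inhibition of growth and lower numbers for stronger inhibition of growth), compound 2 stands as the higher of the two measured numbers, so it restrains growth less strongly than compound 1, and that gap lies beyond the usual scatter of repeats. Compound 3 (`COc1ccc2c(c1)/C(=C\c1cc(OC)c(OC)c(OC)c1)C(=O)N2C`) differs from compound 2 in one place: methyl in place of hydrogen on an oxygen on an aromatic ring puts methyl in place of hydrogen on an oxygen on an aromatic ring, which turns hydroxy into methoxy. For the measured compounds named here, no measured pair shows this change, so any forecast is loose. Compound 1 also carries no hydroxy group and gives 1800 nM in the same test, so a small move toward a lower number is expected, possibly within the scatter. The estimated change is a 1.5-fold lower number from compound 2 to compound 3 (0.19 log units; within the scatter) in size. For compound 3 the expected value is 2800 nM (900 nM to 9000 nM).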

Compound 3, concentration for 50% growth inhibition: 2600 nM
Compound 3: the middle estimate sits 1.1-fold (0.03 log units) above what was measured, within the range that was stated.
By their numbers in this assay, from the lowest: compounds 1, 3 and 2 (each within the scatter of the next, the first and the last beyond it).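

For the compounds shown here, the step of a 1.7-fold lower number from compound 2 to compound 3 (0.22 log units; within the scatter) in this assay is the first direct reading of methyl in place of hydrogen on an oxygen on an aromatic ring, which turns hydroxy into methoxy. The two compounds cannot be told apart here, so the hydrogen on that oxygen is not needed for the growth inhibition seen at this level, and a small methyl is tolerated in its place. No supporting measurement is available to explain this result.

Still open, going by these compounds, is how far this tolerance extends: an ethoxy group or a longer chain on the same oxygen might read differently, and so might an amine in place of the oxygen. A single step in one test on cancer cells also cannot show whether the same change would behave alike on other members of the series.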